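Swapping the Aryl Group on the Ketone

The source may report more compounds than this note shows. Statements on the series, on what has been measured and on what is new or still open speak of the compounds shown alone.

Measured so far:
Compound 1, `CC1(C)C=C(n2ccccc2=O)c2ccccc2O1`: 5.05
Compound 2, `CC1(C)C=C(n2ccccc2=O)c2cc(C(=O)c3ccc(O)cc3)ccc2O1`: 5.87

Both were tested in a functional assay (trachea) with Rattus norvegicus as the target; a higher number here means a more potent compound, by a factor of ten per unit of this negative logarithm, a lower number a less potent compound. Compound 2 stands highest of the two numbers shown; its nearest neighbour is compound 1, and the step of a number 0.82 log units higher from compound 1 to compound 2 (beyond the scatter) came from placing (4-hydroxyphenyl)carbonyl in place of hydrogen on an aromatic carbon of the shared core.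

Compound 3, `Cc1ccccc1C(=O)c1ccc2c(c1)C(n1ccccc1=O)=CC(C)(C)O2`, keeps that carbonyl but changes the ring hanging from it: 2-methylphenyl in place of 4-hydroxyphenyl on a carbonyl carbon. Among the compounds with values here, the one measured step bears on it only loosely, since it shows that the whole (4-hydroxyphenyl)carbonyl group helped, not which of its parts mattered. Within the data shown here, no measured pair separates the hydroxyl from the rest of that group, so the effect of trading it for a methyl on a ring of carbon only is open. A small loss, or no step beyond the scatter, seems the safer expectation, with a wide range.

Compound 3 is therefore expected to give about 5.6, between 5.1 and 6.2, which would be a step of a number 0.27 log units lower from compound 2 to compound 3 (within the scatter).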

Compound 3, logarithm of the reciprocal of the active concentration, log(1/C): 6.25
Estimate against measurement, compound 3: 0.65 log units below; measured number above the stated range.
By their numbers in this assay, from the lowest: compound 1; then compound 2; then compound 3.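

In this assay, the change from 4-hydroxyphenyl to 2-methylphenyl on the carbonyl carbon gives a number 0.38 log units higher from compound 2 to compound 3 (beyond the scatter), so the hydroxyl of compound 2 is not required for activity in this series: compound 3 carries no hydrogen-bond donor or acceptor on that ring, yet it has the higher number. The aryl group on the ketone is therefore more than a passive passenger, and the full gain from adding (2-methylphenyl)carbonyl in place of hydrogen on an aromatic carbon is a number 1.20 log units higher from compound 1 to compound 3 (beyond the scatter), a large step compared with the modest one seen for the (4-hydroxyphenyl)carbonyl group. No measured evidence is available to explain why this swap raises the number.

This swap removes a hydroxyl, adds a methyl and changes where the substituent sits on the ring all at once, so plain phenyl, 4-methylphenyl and 2-hydroxyphenyl would be needed to tell those three changes apart. From the compounds shown here alone, it also remains open how this position responds to an amine or a carboxylic acid on that ring, or to a longer chain such as ethyl in place of the methyl.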